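The source may report more compounds than this note shows. Statements on the series, on what has been measured and on what is new or still open speak of the compounds shown alone.

In a functional assay for inhibition, read by fluorescence and spectrophotometry, with a stated time of 30 h (a higher number here means a weaker inhibitor, a lower number a stronger inhibitor), compound 1 `COc1ccc(-c2cc(=O)c3ccc(O)cc3o2)cc1OC` gives 47400 nM and compound 2 `COc1cc(-c2cc(=O)c3ccc(O)cc3o2)cc(OC)c1OC` gives 51400 nM. Compound 3 `COc1ccc(-c2cc(=O)c3ccc(OCCCCN4CCC(CCO)CC4)cc3o2)cc1` gives 38400 nM, a value within the scatter of the values for both compound 1 and compound 2. Compound 4 `COc1ccc(-c2cc(=O)c3ccc(OCCCCCCN4CCC(C)CC4)cc3o2)cc1` departs from compound 3 as follows: 2-(4-methylpiperidin-1-yl)ethyl in place of 4-(2-hydroxyethyl)piperidin-1-yl on a saturated chain carbon, four bonds along the chain from an oxygen on an aromatic ring. That is, 2-(4-methylpiperidin-1-yl)ethyl stands in place of 4-(2-hydroxyethyl)piperidin-1-yl on a saturated chain carbon, four bonds along the chain from an oxygen on an aromatic ring. For the measured compounds named here, only one measured step is available, a 1.1-fold higher number from compound 1 to compound 2 (0.04 log units; within the scatter), and it is a different change, methoxy in place of hydrogen on an aromatic carbon. Going by the values given here, it therefore bears on this change only indirectly, and no measured pair tests this exchange itself. All three values lie close together, so no step beyond the scatter is expected in this assay, and the direction remains uncertain. The expected step is a 1.5-fold lower number from compound 3 to compound 4 (0.19 log units; within the scatter). For compound 4 the estimated value is 25000 nM, with an expected range of 6000 nM to 70000 nM.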

Compound 4, half-maximal inhibitory concentration: 57200 nM
Compound 4: middle estimate off by 2.3-fold (0.36 log units), on the low side, within the range that was stated.
By their numbers in this assay, from the lowest: compounds 3, 1, 2 and 4 (each within the scatter of the next).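

In this assay the exchange at this position, on a saturated chain carbon four bonds along the chain from an oxygen on an aromatic ring, gives a 1.5-fold higher number from compound 3 to compound 4 (0.17 log units; within the scatter) and so stays inside the scatter. The entering 2-(4-methylpiperidin-1-yl)ethyl has no hydrogen-bond donor, whereas the leaving 4-(2-hydroxyethyl)piperidin-1-yl has one, and in these two compounds that difference brings no step beyond the scatter. No measurement is at hand that would explain this result.

Compound 3 and compound 4 differ in the hydroxyl group and in the placing of the piperidine on the chain together, so these compounds do not separate the two. Going by these compounds, whether a carboxylic acid or a morpholine at the chain end, or a longer chain, would move the number beyond the scatter remains open.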